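A few compounds are considered here, and "the series" means these few. Any claim that something is new, unique, unknown or untested is made for them only; others in the source may bear on it.

Measured so far in a functional assay on SK-MEL-5 cells (Homo sapiens) for inhibition, read by sulforhodamine B assay, with a stated time of 48 h, tested at 10 uM; a lower number here means less inhibition, a higher number more inhibition at the concentration tested (going by the name of the read-out):
compound 1 `c1cn2cc(-c3ccsc3)nc(-c3ccc4ncn(C5CCCCC5)c4c3)c2n1` — 25%
compound 2 `CC(=O)c1ccc(-c2cn3ccnc3c(-c3ccc4ncn(C5CCCCC5)c4c3)n2)cc1` — 24.8%

Compound 2 stands within the scatter of compound 1, so the two numbers are not set apart. For the measured compounds named here, the single measured step, a number 0.2 percentage points lower from compound 1 to compound 2 (within the scatter), swapped the group on an aromatic carbon of the shared core and stayed within the scatter.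

Compound 3 `Brc1ccc(-c2cn3ccnc3c(-c3ccc4ncn(C5CCCCC5)c4c3)n2)cc1` differs from compound 2 by bromo in place of acetyl on an aromatic carbon. Going by the values given here, only the step from compound 1 to compound 2 bears on this position, and it was small, so the expected step is a number 0.2 percentage points higher from compound 2 to compound 3 (within the scatter), none beyond the scatter. Compound 3 is expected to give 25%, with a range of 10% to 40%.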

Compound 3, a percentage reported as inhibition, at one concentration (the size of the read-out at that concentration, not a potency): 23.6%
The estimate for compound 3 lay 1.4 percentage points above the measured number; the range from low to high includes it.
By their numbers in this assay, from the lowest: compounds 3, 2 and 1 (each within the scatter of the next).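

Bromo in place of acetyl, on an aromatic carbon para to a large group, gives a number 1.2 percentage points lower from compound 2 to compound 3 (within the scatter) in this assay, so a single bromine atom and the three heavy atoms of acetyl are not set apart here. The other step, a number 1.4 percentage points lower from compound 1 to compound 3 (within the scatter), shows that 4-bromophenyl and thiophen-3-yl are not set apart either. Nothing measured here offers a reason for these numbers staying together.

As far as these compounds go, whether an amine or a carboxylic acid at this place would give a step beyond the scatter stays open.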